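Swapping trifluoromethyl for fluoro on the pendant phenyl

The source may hold more compounds than are shown below. What is called first, only, known or untested is meant among the compounds shown, and "the series" means these compounds.

Measured so far:
- compound 1, `Cc1ccc2c(=O)[nH]c(-c3cccc(F)c3)nc2c1`, 4.3%
- compound 2, `Cc1ccc2nc(-c3ccccc3C(F)(F)F)[nH]c(=O)c2c1`, 21.1%
- compound 3, `CCN(CC)c1ccc2nc(-c3ccccc3C(F)(F)F)[nH]c(=O)c2c1`, 13.3%

In an assay on isolated protein for inhibition of DNA topoisomerase 1 (Homo sapiens), with a stated time of 30 min, tested at 20 uM (on this read-out lower numbers stand for a weaker effect and higher numbers for a stronger effect at the one concentration tested), compound 2 stands highest of the three numbers. Compound 3 sits within the scatter of it, the step being a number 7.8 percentage points lower from compound 2 to compound 3 (within the scatter). Compound 1 lies beyond the scatter below compound 2, but the two differ in more than one place, so their values show only that a fluoro-bearing phenyl on this core can go with a low number.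

Compound 4, `Cc1ccc2nc(-c3ccccc3F)[nH]c(=O)c2c1`, is not yet measured. It differs from compound 2 in one place: fluoro in place of trifluoromethyl on an aromatic carbon. For the measured compounds named here, no measured step changes exactly this group, so the one step in hand, from compound 2 to compound 3 on a different part of the core, says little. Going by the values given here, what the numbers of compound 1 and compound 2 show is that the compound with the trifluoromethyl group is the one with the higher number. On that basis the step is expected to be downward, a number 11.1 percentage points lower from compound 2 to compound 4 (beyond the scatter), with wide uncertainty. Compound 4 is therefore estimated at 10%, in a range from 0% to 24%.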

Compound 4, a percentage reported as inhibition, at one concentration (the size of the read-out at that concentration, not a potency): 36.3%
Beside the measured number, compound 4's estimate is 26.3 percentage points below it, and the stated range ends below it.
By their numbers in this assay, from the lowest: compounds 1, 3 and 2 (each within the scatter of the next, the first and the last beyond it); then compound 4.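

In this assay the change from trifluoromethyl to fluoro on this aromatic carbon gives a number 15.2 percentage points higher from compound 2 to compound 4 (beyond the scatter) and is the only step shown at this position. It shows that trifluoromethyl is not needed here for the number seen with compound 2, since the group with one heavy atom goes with a stronger effect at the one concentration tested than the group with four. Nothing measured on these compounds bears on why the number moves this way.

Whether the same gain appears with diethylamino in place of methyl on the core stays open, as that group is shown only with trifluoromethyl in compound 3. Also open, as far as these compounds go, is how chloro, methoxy or plain hydrogen on the same aromatic carbon would compare, and so whether the number follows the size of the group at all.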